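Acetyl in place of hydroxy on a quinoline acid

The source may report more compounds than this note shows. Statements on the series, on what has been measured and on what is new or still open speak of the compounds shown alone.

Of the compounds shown here, two have been measured in an assay on isolated protein with malate dehydrogenase, mitochondrial (Sus scrofa) as the target; a lower number here means a stronger inhibitor, a higher number a weaker inhibitor. Compound 1 `O=C(O)c1ccc2c(O)c(C(=O)O)cnc2c1` gives 1070000 nM, and compound 2 `O=C(O)c1cnc2cc(O)ccc2c1O` gives 490000 nM, the lower of the two numbers. The change was a 2.2-fold lower number from compound 1 to compound 2 (0.34 log units; beyond the scatter). Compound 3 `CC(=O)c1ccc2c(O)c(C(=O)O)cnc2c1` differs from compound 2 by acetyl in place of hydroxy on an aromatic carbon. Among the measured compounds shown here, only that one step bears on this change, and it was modest, so no large move is expected; the step from compound 2 to compound 3 is estimated at a 1.4-fold higher number from compound 2 to compound 3 (0.15 log units; within the scatter). Compound 3 is therefore expected to give about 700000 nM, within 250000 nM to 2000000 nM.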

Compound 3, half-maximal inhibitory concentration: 912000 nM
The estimate for compound 3 lay 1.3-fold (0.11 log units) below the measured number; the measured number falls inside the stated range.
By their numbers in this assay, from the lowest: compounds 2, 3 and 1 (each within the scatter of the next, the first and the last beyond it).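

In this assay the swap on this aromatic carbon gives a 1.9-fold higher number from compound 2 to compound 3 (0.27 log units; within the scatter) and the acetyl brings no hydrogen-bond donor, so the donor of the hydroxy is not shown to matter here. Methyl in place of hydroxy on the carbonyl carbon gives a 1.2-fold lower number from compound 1 to compound 3 (0.07 log units; within the scatter) and so compound 3 cannot be told apart from either neighbour, although compound 1 and compound 2 differ beyond the scatter. No measurement here accounts for these small steps. From the compounds shown here alone, whether an amine or a longer chain on this carbon would move the number beyond the scatter stays open.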